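Benzyl in place of butyl on a guanine-type nucleoside

A few compounds are considered here, and "the series" means these few. Any claim that something is new, unique, unknown or untested is made for them only; others in the source may bear on it.

Compound 2 `CCCCn1c(=O)n(C2OC(CO)[C@@H](O)[C@H]2O)c2nc(N)nc(O)c21` holds the lowest of the two numbers measured in a functional assay (B cells) with Mus musculus as the target (a lower number here means that less compound is needed, a higher number that more compound is needed for the effect), giving 11 uM; compound 1 `Nc1nc(O)c2c(n1)n(C1OC(CO)[C@@H](O)[C@H]1O)c(=O)n2Cc1ccc(Cl)cc1` gives 14 uM, and the step of a 1.3-fold lower number from compound 1 to compound 2 (0.10 log units; within the scatter) lies within the scatter. Compound 3 `Nc1nc(O)c2c(n1)n(C1OC(CO)[C@@H](O)[C@H]1O)c(=O)n2Cc1ccccc1` differs from compound 2 by phenyl in place of propyl on a saturated chain carbon bound to an aromatic nitrogen. Going by the values given here, the only step that bears on this change, from compound 1 to compound 2, is within the scatter, so for compound 3 no step beyond the scatter is expected in either direction. Compound 3 is therefore estimated at 12 uM, with a range of 5 uM to 30 uM, a step of a 1.1-fold higher number from compound 2 to compound 3 (0.04 log units; within the scatter).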

Compound 3, concentration for half-maximal effect: 6 uM
Beside the measured number, compound 3's estimate is 2.0-fold (0.30 log units) above it; measured number inside the range.
By their numbers in this assay, from the lowest: compounds 3, 2 and 1 (each within the scatter of the next, the first and the last beyond it).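

In this assay, phenyl in place of propyl on a saturated chain carbon bound to an aromatic nitrogen gives a 1.8-fold lower number from compound 2 to compound 3 (0.26 log units; within the scatter) and so leaves butyl and benzyl at this place within the scatter of each other. Hydrogen in place of chloro on an aromatic carbon gives a 2.3-fold lower number from compound 1 to compound 3 (0.37 log units; beyond the scatter) and is the only step so far beyond the scatter, though a modest one. Nothing on hand accounts for either step. From the compounds shown here alone, whether a longer chain in place of butyl would give a step beyond the scatter remains open. So does the effect of an amine or a carboxylic acid in place of the chloro on that aromatic carbon.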